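The source may report more compounds than this note shows. Statements on the series, on what has been measured and on what is new or still open speak of the compounds shown alone.

Compound 2 `CN1C(=O)C=C(Cl)C1(O)c1ccc(Cl)cc1` gives 2000 nM in an assay on cell membranes for displacement of a labelled ligand from Cholecystokinin receptor type A (Rattus norvegicus), read by CCK-8 assay, with a stated time of 2 h; a lower number here means a stronger inhibitor, a higher number a weaker inhibitor. Among the three measured numbers it stands second highest: compound 1 `CN1C(=O)C=C(Cl)C1(O)c1ccccc1` gives 2500 nM, and the step of a 1.3-fold lower number from compound 1 to compound 2 (0.10 log units; within the scatter) lies within the scatter, while compound 3 `O=C1C=C(Cl)C(O)(c2ccccc2)N1C1CCCC1` gives 360 nM, a number beyond the scatter from compound 2. Compound 4 `CCCCCCN1C(=O)C=C(Cl)C1(O)c1ccc(Cl)cc1` differs from compound 2 by pentyl in place of hydrogen on a saturated chain carbon bound to an amide-type nitrogen in a ring. The measured step that bears on this is a 6.9-fold lower number from compound 1 to compound 3 (0.84 log units; beyond the scatter), where cyclopentyl in place of methyl on the amide-type nitrogen in the ring lowered the number modestly. A drop of similar size is therefore expected for compound 4, so the estimated step is a 5.0-fold lower number from compound 2 to compound 4 (0.70 log units; beyond the scatter). Compound 4 is expected to give about 400 nM in this assay, within a range of 150 nM to 1100 nM.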

Compound 4, half-maximal inhibitory concentration: 3600 nM
Estimate against measurement, compound 4: 9.0-fold (0.95 log units) below, outside the stated range (above it).
By their numbers in this assay, from the lowest: compound 3; then compounds 2, 1 and 4 (each within the scatter of the next).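

In this assay, methyl to hexyl on the amide-type nitrogen in the ring gives a 1.8-fold higher number from compound 2 to compound 4 (0.26 log units; within the scatter), whereas cyclopentyl in place of methyl there gave a 6.9-fold lower number from compound 1 to compound 3 (0.84 log units; beyond the scatter). Adding carbon at this nitrogen therefore does not by itself lower the number, although these two steps start from cores differing by one chloro. Nothing available explains this contrast. From the compounds shown here alone, it remains open whether cyclopentyl would lower the number on the core of compound 2, and what a shorter chain such as propyl, or a chain ending in an amine, would do at this nitrogen.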